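Swapping the 4-nitrophenyl group in compound 2

The compounds below may be only part of what the source reports. "The series", "measured", "known", "first", "only" and "open" are said of these compounds alone.

- Compound 1 `O=C(N/N=C/c1ccc(F)cc1Cl)Nc1cc2c(Nc3ccc(F)c(Cl)c3)ncnc2cc1O[C@H]1CCOC1`: 32200 nM
- Compound 2 `COc1cc2ncnc(Nc3ccc(F)c(Cl)c3)c2cc1NC(=O)N/N=C/c1ccc([N+](=O)[O-])cc1`: 36800 nM

Both values come from a functional assay on MCF7 cells (Homo sapiens) for cytotoxicity, read by MTT assay, with a stated time of 72 h; on this read-out lower numbers stand for stronger inhibition and higher numbers for weaker inhibition. Compound 2 stands level with compound 1, since their two numbers lie within the usual scatter of each other.

Compound 3 `COc1cc2ncnc(Nc3ccc(F)c(Cl)c3)c2cc1NC(=O)N/N=C/c1ccc(F)cc1Cl` keeps the rest of compound 2 and changes one group: 2-chloro-4-fluorophenyl in place of 4-nitrophenyl on a carbon with a double bond to nitrogen. In words, 2-chloro-4-fluorophenyl comes in place of 4-nitrophenyl on a carbon with a double bond to nitrogen.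

Among the compounds with values here, no measured pair shows this change on its own, so there is no direct step to lean on. Within the data shown here, the only guide is that the entering 2-chloro-4-fluorophenyl group also sits on compound 1, which gives 32200 nM in this assay, a number close to that of compound 2. The expectation is therefore no step beyond the scatter in this assay, in either direction. The estimated change is a 1.2-fold lower number from compound 2 to compound 3 (0.07 log units; within the scatter). Compound 3 is expected at 31000 nM, with an estimated range of 13000 nM to 70000 nM.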

Compound 3, half-maximal inhibitory concentration: "not active" (no number reported)
Nothing numeric was reported for compound 3; the estimate stays without a comparison.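

In this assay, within the data shown here, compound 3 is reported only as "not active", with no number, so no step from compound 2 to compound 3 can be read. On these data alone, how far 2-chloro-4-fluorophenyl in place of 4-nitrophenyl moves the number on this core stays open. No measurement shown here offers an explanation for the "not active" report.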